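Removing a Methyl from a Thiosemicarbazide Pyridine Amidrazone

The compounds below may be only part of what the source reports. "The series", "measured", "known", "first", "only" and "open" are said of these compounds alone.

Of the compounds shown here, two have been measured so far. Compound 1 `N/C(=N\NC(=S)N1CCOCC1)c1ccccn1` gives 4800 nM in a functional assay on A-431 cells (Homo sapiens) for cytotoxicity, read by MTT assay, with a stated time of 72 h (on this read-out higher numbers stand for weaker inhibition and lower numbers for stronger inhibition), and compound 2 `Cc1cccc(/C(N)=N/NC(=S)N2CCCC2)n1` gives 4000 nM in this assay. Compound 2 has the lowest of the two numbers, but its nearest neighbour, compound 1, stands only a small distance away, within the usual scatter of repeated measurements, so no order between the two can be claimed; the pair also differs in more than one place, so their two values are all that can be said of them.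

Compound 3 `N/C(=N\NC(=S)N1CCCC1)c1ccccn1` has not yet been measured in this assay. It is compound 2 with hydrogen in place of methyl on an aromatic carbon. Within the data shown here, no measured pair shows this change directly. Since compound 1, which also carries hydrogen at this carbon, gives 4800 nM, the step from compound 2 to compound 3 is expected to stay within the scatter, with no clear direction, as a 1.1-fold higher number from compound 2 to compound 3 (0.05 log units; within the scatter). Compound 3 is therefore estimated at 4500 nM, in a range from 2000 nM to 10000 nM.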

Compound 3, half-maximal inhibitory concentration: 1700 nM
Compound 3: middle estimate off by 2.6-fold (0.42 log units), on the high side; the whole stated range lies above it.
By their numbers in this assay, from the lowest: compound 3; then compounds 2 and 1 (each within the scatter of the next).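

In this assay, the aromatic carbon next to the ring nitrogen proves sensitive to what it carries: hydrogen in place of methyl there gives a 2.4-fold lower number from compound 2 to compound 3 (0.37 log units; beyond the scatter), a modest step beyond the scatter. The group on the thiocarbonyl carbon matters as well, as pyrrolidin-1-yl in place of morpholin-4-yl gives a 2.8-fold lower number from compound 1 to compound 3 (0.45 log units; beyond the scatter), also modest. Compounds 1 and 2 lie within the scatter of each other, yet each is one change away from compound 3, so their closeness had concealed two separate steps, and only the combination of hydrogen on the aromatic carbon with pyrrolidin-1-yl on the thiocarbonyl carbon stands apart; nothing available explains either step.

As far as these compounds go, each change has been read in only one setting, so it remains open whether removing the methyl would give a similar step with morpholin-4-yl on the thiocarbonyl carbon. Also open, from the compounds shown here alone, is how a methoxy group or a chlorine atom on the aromatic carbon, or piperidin-1-yl on the thiocarbonyl carbon, would compare with the groups seen so far.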